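The source may report more compounds than this note shows. Statements on the series, on what has been measured and on what is new or still open speak of the compounds shown alone.

Measured so far in an assay on isolated protein for inhibition of malate dehydrogenase, mitochondrial (Sus scrofa), with stated times of 45 min and 30 min; a lower number here means a stronger inhibitor, a higher number a weaker inhibitor:
Compound 1, `O=S(=O)(Nc1ccc(-c2nc3ccccc3o2)cc1)c1ccc(Cl)s1`, gives > 63000 nM, which is a limit of this assay.
Compound 2, `C=Cc1ccc(S(=O)(=O)Nc2ccc(-c3nc4ccccc4o3)cc2)cc1`, gives > 63000 nM, also a limit.
Compound 3, `CCc1ccc(S(=O)(=O)Nc2ccc(-c3nc4ccccc4o3)cc2)cc1`, gives > 63000 nM, again a limit.

Compound 3 therefore stands at the same limit as the other two, and nothing among the three values places it above or below them. The three steps between these compounds, a step that the two limits leave unreadable from compound 1 to compound 2, a step that the two limits leave unreadable from compound 1 to compound 3 and a step that the two limits leave unreadable from compound 2 to compound 3, are all unreadable, since every value involved is a limit; this is summed up by the limit of > 63000 nM in this assay, at which 3 of the 3 values shown sit.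

Compound 4, `O=S(=O)(Nc1ccc(-c2nc3ccccc3o2)cc1)c1ccc(Cl)cc1`, is the next compound to be measured in this assay. It differs from compound 3 as follows: chloro in place of ethyl on an aromatic carbon. The step from compound 2 to compound 3 touches the same aromatic carbon, but its size cannot be read. Going by the values given here, no measured step therefore gives a usable size or direction, and the three limits together point to another limit rather than a number. The estimated step, a step that the limit leaves unreadable from compound 3 to compound 4, is expected to stay within the scatter. Compound 4 is expected to give about 80000 nM, within a range from 30000 nM to 250000 nM.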

Compound 4, half-maximal inhibitory concentration: > 63000 nM
Compound 4 gave a limit, no number; the forecaster's own chance of this, stated with the estimate: 85%; the middle value does not contradict the limit.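

In this assay compound 4 gives > 63000 nM, which is a limit, so its steps from compound 1, compound 2 and compound 3 cannot be read. All four compounds stand at one value: the limit of > 63000 nM in this assay, at which 4 of the 4 values shown sit.

The compounds shown leave open which group on the sulfonyl sulfur, if any, would give a measurable number.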